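The compounds below may be only part of what the source reports. "The series", "measured", "known", "first", "only" and "open" are said of these compounds alone.

Compound 1 `CNc1nc(N)c2nc(O)n(Cc3ccccc3)c2n1`: 1 uM
Compound 2 `CCCSc1nc(N)c2nc(O)n(Cc3ccccc3)c2n1`: 0.01 uM
Compound 3 `Nc1ncnc2c1nc(O)n2Cc1ccccc1`: 10 uM

These three compounds share one core and differ only at a single aromatic carbon. In a functional assay (spleen, spleen) for activation, with Mus musculus as the target (a higher number here means that more compound is needed for the effect, a lower number that less compound is needed), compound 3, which carries a hydrogen at that carbon, has the highest number of the three: compound 1 sits closest, a 10-fold higher number from compound 1 to compound 3 (1.00 log units; beyond the scatter), and compound 2 sits furthest, a 1000-fold higher number from compound 2 to compound 3 (3.00 log units; beyond the scatter). Both steps show that putting a group on that carbon in place of hydrogen lowers the number, and that the larger propylsulfanyl group lowers it far more than methylamino.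

Compound 4 `COc1nc(N)c2nc(O)n(Cc3ccccc3)c2n1` is not yet measured. Its change from compound 3 is methoxy in place of hydrogen on an aromatic carbon. Methoxy matches methylamino in size more closely than propylsulfanyl, so the step resembling a 10-fold higher number from compound 1 to compound 3 (1.00 log units; beyond the scatter) reversed is the better guide, with the larger effect seen in compound 2 pulling the expectation somewhat further. Compound 4 is therefore expected to give 0.3 uM, within a range of 0.03 uM to 3 uM. That estimate corresponds to an expected step of a 33-fold lower number from compound 3 to compound 4 (1.52 log units; beyond the scatter) in this assay.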

Compound 4, minimum effective concentration: 0.1 uM
Estimate against measurement, compound 4: 3.0-fold (0.48 log units) above, within the range that was stated.
By their numbers in this assay, from the lowest: compound 2; then compound 4; then compound 1; then compound 3.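

In this assay, methoxy on the aromatic carbon between two ring nitrogen atoms lowers the number well beyond the scatter (a 100-fold lower number from compound 3 to compound 4 (2.00 log units; beyond the scatter)), so a group of 2 heavy atoms is enough for a large step. Swapping the methylamino of compound 1 for methoxy also changes the number (a 10-fold lower number from compound 1 to compound 4 (1.00 log units; beyond the scatter)), while methoxy still falls short of propylsulfanyl (a 10-fold higher number from compound 2 to compound 4 (1.00 log units; beyond the scatter)), which places methoxy between those two groups. No measurement shown here explains these differences. From the compounds shown here alone, whether the sulfur or the longer chain sets propylsulfanyl apart remains open, and propoxy and propylamino would separate the two.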